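This account rests on a few compounds, and the source may have more. Where it says the series, first, only, none or still open, it means among the compounds named here.

Compound 1 `Cc1ccc(NC(=O)Nc2cccc(CNc3nccnc3Cl)c2)c(C)c1`: 9230 nM
Compound 2 `O=C(Nc1cccc(CNc2nccnc2Cl)c1)NC1CCCC1`: > 40000 nM, a limit of the assay
Compound 3 `CCc1ccccc1NC(=O)Nc1cccc(CNc2nccnc2Cl)c1`: 8720 nM

In a functional assay on T-24 cells (Homo sapiens) for antiproliferative activity, read by MTT assay, with a stated time of 48 h (a higher number here means a weaker inhibitor, a lower number a stronger inhibitor), compound 3 stands level with the other phenyl-bearing compound: a 1.1-fold lower number from compound 1 to compound 3 (0.02 log units; within the scatter). Compound 4 `O=C(Nc1cccc(CNc2nccnc2Cl)c1)NC1CCCCC1` has cyclohexyl in place of 2-ethylphenyl on an amide-type nitrogen. The closest measured change is the exchange involving the cyclopentyl of compound 2, which gave an at least 4.3-fold higher number from compound 1 to compound 2 (0.63 log units; beyond the scatter) and, in reverse, an at least 4.5-fold lower number from compound 2 to compound 3 (0.66 log units; beyond the scatter). Both sizes rest on (the limit of > 40000 nM in this assay, at which 1 of the 3 values shown sits), so the true gap may be larger. A similar rise beyond the scatter is therefore expected here, and the estimated step is a 3.4-fold higher number from compound 3 to compound 4 (0.54 log units; beyond the scatter). For compound 4 the estimate is 30000 nM, with an expected range of 14000 nM to 60000 nM.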

Compound 4, half-maximal inhibitory concentration: > 40000 nM
Compound 4 was reported as a limit; the forecaster's own chance of this, stated with the estimate: 45%; middle value at least 1.3-fold (0.12 log units) away from the limit.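

In this assay cyclohexyl in place of 2-ethylphenyl on the amide-type nitrogen gives an at least 4.5-fold higher number from compound 3 to compound 4 (0.66 log units; beyond the scatter) and cyclohexyl in place of 2,4-dimethylphenyl gives an at least 4.3-fold higher number from compound 1 to compound 4 (0.63 log units; beyond the scatter). The loss seen with cyclopentyl is thus not confined to that one group, since a second non-aromatic ring of carbon only also reaches the limit, while both aromatic compounds keep a readable number. The step from compound 2 to compound 4 cannot be read, and the two readable steps give only a minimum size: the limit of > 40000 nM in this assay, at which 2 of the 4 values shown sit.

From the compounds shown here alone, whether an unsubstituted phenyl, a pyridine ring or an open chain such as n-butyl on this nitrogen would give a readable number remains open.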